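This account rests on a few compounds, and the source may have more. Where it says the series, first, only, none or still open, it means among the compounds named here.

Measured so far in a functional assay on U-251 cells (Homo sapiens) for inhibition, read by sulforhodamine B assay, with a stated time of 48 h; a lower number here means a stronger inhibitor of growth, a higher number a weaker inhibitor of growth:
- compound 1 `CC1=CC[C@H](C(C)(C)NC(=S)N/N=C/c2ccc(O)cc2)CC1` — reported only as a limit, > 100000 nM
- compound 2 `CC1=CC[C@H](C(C)(C)NC(=S)N/N=C/c2ccc(N(C)C)cc2)CC1` — reported only as a limit, > 100000 nM

Among the compounds with values here, compound 1 stands nowhere on a numerical scale in this assay: its result is a limit, and the one further value shown is a limit as well. Within the data shown here, the single measured step, a step that the two limits leave unreadable from compound 1 to compound 2, cannot be read because both of its ends sit at the limit of > 100000 nM in this assay, at which 2 of the 2 values shown sit. Compound 3 `CC1=CC[C@H](C(C)(C)NC(=S)N/N=C/c2ccccc2Cl)CC1` differs from compound 1 by 2-chlorophenyl in place of 4-hydroxyphenyl on a carbon with a double bond to nitrogen. Among the measured compounds shown here, no measured step covers this exchange, and the one step that exists gives no size, so nothing points to a shift beyond the scatter in either direction. Compound 3 is therefore expected to give about 150000 nM in this assay, within 50000 nM to 500000 nM, and most probably to be reported again only as a limit. The expected step is a step that the limit leaves unreadable from compound 1 to compound 3.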

Compound 3, concentration for total growth inhibition: > 100000 nM
Compound 3: no number, only a limit (the forecaster's own chance of this, stated with the estimate: 80%); the middle value is on the limit's open side.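

No step can be read from compound 1 to compound 3 in this assay, as compound 3 gives no number and joins compound 1 and compound 2 at the limit: the limit of > 100000 nM in this assay, at which 3 of the 3 values shown sit.

The compounds shown leave open whether any exchange of the aromatic group on the shared core would give a readable value in this assay.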